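The source may report more compounds than this note shows. Statements on the series, on what has been measured and on what is new or still open speak of the compounds shown alone.

Measured so far:
compound 1 `CN(C)c1ccc(-c2nc3c(s2)C(O)CNC3)cc1`, 170 nM
compound 2 `OCc1cc(N2CCCC2)ccc1-c1nc2c(s1)C(O)CCC2`, 32 nM

Of the compounds shown here, two have been tested in a functional assay on MDA-MB-361 cells (Homo sapiens) for cytotoxicity, read by sulforhodamine B assay, with a stated time of 2 days; on this read-out lower numbers stand for stronger inhibition and higher numbers for weaker inhibition. Compound 1 gives 170 nM, the higher of the two numbers, and compound 2 gives 32 nM, a gap that lies beyond the scatter of repeated measurements. Compound 2 differs from compound 1 in several places at once, so no single change can be held responsible for that gap.

Compound 3 `OC1CNCc2nc(-c3ccc(N4CCCC4)cc3)sc21` has not yet been measured. It differs from compound 1 in one place: pyrrolidin-1-yl in place of dimethylamino on an aromatic carbon. Compound 2 also carries a pyrrolidin-1-yl group on its outer ring and gives the lower number, but its other differences from compound 1 leave that observation only as a loose hint. On that basis the step from compound 1 to compound 3 is expected to be modest and towards a lower number, though a step that stays within the scatter would not be surprising.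

Compound 3 is therefore expected to give 100 nM in this assay, within a range from 40 nM to 300 nM, which is the step of a 1.7-fold lower number from compound 1 to compound 3 (0.23 log units; within the scatter).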

Compound 3, half-maximal inhibitory concentration: 140 nM
For compound 3 the middle estimate is 1.4-fold (0.15 log units) below the measured one, within the range that was stated.
By their numbers in this assay, from the lowest: compound 2; then compounds 3 and 1 (each within the scatter of the next).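

In this assay, placing pyrrolidin-1-yl in place of dimethylamino on an aromatic carbon, para to a large group, gives a 1.2-fold lower number from compound 1 to compound 3 (0.08 log units; within the scatter). Going by these compounds alone, this is the first comparison here in which only one place differs, and it shows that a group with five heavy atoms and a five-membered ring can replace one with three heavy atoms and no ring without a difference beyond the scatter, so this pair of compounds cannot be told apart in this read-out. No measured property of either group accompanies this result, so the data offer no explanation for it.

Within the data shown here, this single step covers only two closely related groups, both joined to the aromatic ring through a nitrogen, so it remains open how the read-out would respond at this position to a morpholin-4-yl group, a carboxylic acid or a longer chain. The rest of the shared core is identical in this pair, so the step also says nothing about how changes elsewhere in the core would affect the read-out.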